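This account rests on a few compounds, and the source may have more. Where it says the series, first, only, none or still open, it means among the compounds named here.

Values measured in an ADME assay on L6 cells (Rattus norvegicus) for cytotoxicity, read by resazurin assay, with a stated time of 72 h; on this read-out higher numbers stand for weaker inhibition and lower numbers for stronger inhibition:

- compound 1 `CN(C)C12CCN(C(=O)CN3CCCCC3)C(C(c3ccccc3)C1)C(c1ccccc1)C2`: 141000 nM
- compound 2 `CN(C)C12CCN(CCN3CCCCC3)C(C(c3ccccc3)C1)C(c1ccccc1)C2`: 135000 nM

These two compounds are all that has been measured so far, and their values lie within the scatter of each other. Compound 2, at 135000 nM, therefore has no meaningful rank, and it stands level with compound 1. The next compound to be tested is compound 3 `CCN(CC)CCN1CCC2(N(C)C)CC(c3ccccc3)C1C(c1ccccc1)C2`. Its difference from compound 2 is diethylamino in place of piperidin-1-yl on a saturated chain carbon, two bonds along the chain from an amine nitrogen in a ring.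

Going by the values given here, no measured step makes this exact exchange. The nearest evidence is a 1.0-fold lower number from compound 1 to compound 2 (0.02 log units; within the scatter), a step that replaced ((piperidin-1-yl)methyl)carbonyl with 2-(piperidin-1-yl)ethyl on an amine nitrogen in a ring. Piperidin-1-yl is present on both sides of that step, so it bears only indirectly on the new change. It does show one alteration of this side chain passing without a shift beyond the scatter. On that slender basis, no step beyond the scatter is expected in this assay.

The expected change is a 1.0-fold lower number from compound 2 to compound 3 (0.02 log units; within the scatter). For compound 3 the estimated value is 130000 nM, with an expected range of 65000 nM to 260000 nM.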

Compound 3, half-maximal inhibitory concentration: 101000 nM
The estimate for compound 3 lay 1.3-fold (0.11 log units) above the measured number; low and high end bracket the measured number.
By their numbers in this assay, from the lowest: compounds 3, 2 and 1 (each within the scatter of the next).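

The direct exchange at this position, on a saturated chain carbon two bonds along the chain from an amine nitrogen in a ring, was the first to replace the piperidin-1-yl ring with open diethylamino, and in this assay it gives a 1.3-fold lower number from compound 2 to compound 3 (0.13 log units; within the scatter) and so leaves the read-out level. The wider change on the ring nitrogen, which alters both the terminal amine and the carbonyl of the side chain, gives a 1.4-fold lower number from compound 1 to compound 3 (0.14 log units; within the scatter) and shows that even these two alterations together stay within the scatter, so all three compounds stand level and the piperidin-1-yl ring is not required to hold the number in this range. No supporting evidence is available to explain this result.

The compounds shown leave open whether a morpholin-4-yl ring, a primary amine or a carboxylic acid at the end of the chain would move the number beyond the scatter. They also leave open whether a longer chain between the ring nitrogen and the terminal amine would do so.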